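The compounds below may be only part of what the source reports. "The series", "measured", "known", "first", "only" and "open" are said of these compounds alone.

Measured so far in a functional assay (mast cells) for inhibition, with Rattus norvegicus as the target; on this read-out lower numbers stand for an effect already at smaller amounts and higher numbers for an effect only at larger amounts of compound:

- compound 1 `CC1CC/C(=N\Nc2cccc(Br)c2)c2ncc(C(=O)O)c(=O)n21` gives 6700 nM 
- compound 2 `Cc1cccc(N/N=C2\CCC(C)n3c2ncc(C(=O)O)c3=O)c1` gives 72900 nM 

Of these two, compound 2 carries the higher number, so an effect appears only at larger amounts than for compound 1. The next compound to read is compound 3 `Cc1ccc(N/N=C2\CCC(C)n3c2ncc(C(=O)O)c3=O)cc1`, which has the same atoms as compound 2 joined differently: 4-methylphenyl in place of 3-methylphenyl on an amine nitrogen. In words, 4-methylphenyl stands in place of 3-methylphenyl on an amine nitrogen.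

For the measured compounds named here, only one measured step bears on this. It is an 11-fold higher number from compound 1 to compound 2 (1.04 log units; beyond the scatter), with methyl in place of bromo on an aromatic carbon. That step is large, but it swaps one group for another, whereas here the same methylphenyl atoms are rearranged. It therefore gives no direction for this change, and no step beyond the scatter is expected in this assay. The range stays wide because an 11-fold higher number from compound 1 to compound 2 (1.04 log units; beyond the scatter) shows that one aromatic change can move the number far.

The step expected here is a 1.2-fold lower number from compound 2 to compound 3 (0.08 log units; within the scatter), an estimate only. For compound 3 the estimated value is 60000 nM, with an expected range from 15000 nM to 200000 nM for this read-out.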

Compound 3, half-maximal effective concentration: 280 nM
Compound 3: middle estimate off by 210-fold (2.33 log units), on the high side; the measured number lies below the stated range.
By their numbers in this assay, from the lowest: compound 3; then compound 1; then compound 2.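

Working notes on the series: in this assay the two methylphenyl compounds hold the same atoms, yet 4-methylphenyl in place of 3-methylphenyl on an amine nitrogen gives a 260-fold lower number from compound 2 to compound 3 (2.42 log units; beyond the scatter) and so shows that the place of the methyl alone can carry a large step, whereas the earlier pair showed only one group exchanged for another. Against the bromo compound, 4-methylphenyl in place of 3-bromophenyl gives a 24-fold lower number from compound 1 to compound 3 (1.38 log units; beyond the scatter) and puts compound 3 lowest of the three, with its steps to both others beyond the scatter. No supporting measurement is available to explain why the 4-methylphenyl and 3-methylphenyl groups differ so widely.

As far as these compounds go, the finding rests on a single pair of methyl isomers, so it remains open whether bromo in place of the methyl of the 4-methylphenyl group would follow the same direction as the methyl and bromo pair already read. From the compounds shown here alone, how an unsubstituted phenyl group, or chloro or methoxy in place of the methyl, would read on the same core also remains open.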